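A few compounds are considered here, and "the series" means these few. Any claim that something is new, unique, unknown or untested is made for them only; others in the source may bear on it.

In an ADME assay on microsomes from liver (Rattus norvegicus) for metabolic stability (a lower number here means that the compound disappears faster, a higher number that the compound lasts longer), compound 1 `CC#C[C@@H](Cc1nnn[nH]1)c1ccc(OCc2ccc3sc(F)c(-c4ccccc4C)c3c2)cc1` gives 0.367 h, while compound 2 `CC#C[C@@H](Cc1nnn[nH]1)c1ccc(OCc2ccc3sc(Cl)c(-c4ccccc4C)c3c2)cc1` gives 1.08 h, the higher of the two numbers. Compound 3 `CC#C[C@@H](Cc1nnn[nH]1)c1ccc(OCc2ccc3sc(I)c(-c4ccccc4C)c3c2)cc1` differs from compound 2 by one change, iodo in place of chloro on an aromatic carbon, next to the ring sulfur. Among the compounds with values here, only one measured step bears on this, the exchange of fluoro for chloro on the same carbon, which gave a 2.9-fold higher number from compound 1 to compound 2 (0.47 log units; beyond the scatter). A single step sets no trend, and nothing yet shows whether the rise continues with iodo. A further small rise in this assay is therefore expected, smaller than the measured step and probably not beyond the scatter. The expected change is a 1.2-fold higher number from compound 2 to compound 3 (0.08 log units; within the scatter). Compound 3 is estimated at 1.3 h, with an expected range of 0.6 h to 2.9 h.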

Compound 3, half-life: 0.483 h
Compound 3: the middle estimate sits 2.7-fold (0.43 log units) above what was measured, and the stated range ends above it.
By their numbers in this assay, from the lowest: compounds 1 and 3 (each within the scatter of the next); then compound 2.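

In this assay, the halogen on this aromatic carbon, next to the ring sulfur, does not give a steady rise from fluoro through chloro to iodo: iodo in place of chloro brings a 2.2-fold lower number from compound 2 to compound 3 (0.35 log units; beyond the scatter) and so undoes most of the earlier gain, which leaves chloro above both other halogens by more than the scatter. Iodo in place of fluoro brings a 1.3-fold higher number from compound 1 to compound 3 (0.12 log units; within the scatter) and stays within the scatter, so among these three compounds the gain belongs to chloro alone and does not follow the order of the halogens. No measurement at hand explains why chloro stands apart.

The compounds shown leave open how bromo, methyl or a nitrile on this carbon would compare with chloro. They also leave open whether chloro would keep its place over fluoro and iodo with another group in place of the 2-methylphenyl group.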